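A few compounds are considered here, and "the series" means these few. Any claim that something is new, unique, unknown or untested is made for them only; others in the source may bear on it.

Measured so far:
compound 1, `O=c1n([C@H]2CO[C@H](CO)O2)cc(F)c2nc(-c3ccc([N+](=O)[O-])cc3)cn12` — in an ADME assay on HepG2 2.2.15 cells (Homo sapiens) for cytotoxicity, read by neutral red uptake (on this read-out higher numbers stand for lower toxicity in this test and lower numbers for higher toxicity in this test), compound 1 gives 587000 nM
compound 2, `O=c1n([C@H]2CO[C@@H](CO)O2)cc(F)c2nc(CO)cn12` — in this assay compound 2 gives 1060000 nM

Among the measured compounds shown here, on these two numbers compound 2 stands highest, but its only neighbour, compound 1, lies within the scatter of it, so no order between the two can be read from this assay. Compound 3 is `O=c1n([C@H]2CO[C@H](CO)O2)cc(F)c2nc(CO)cn12` and has not yet been measured in this assay. Against compound 2 the change is: the two compounds have the same atoms and bonds and differ only in configuration as drawn: 1 of 2 stereo elements differ; a stereocentre at a saturated ring carbon is drawn R in compound 2 and S in compound 3. For the measured compounds named here, no pair of measured compounds differs in exactly one place, so no step of this kind has been seen. Going by the values given here, with only two compounds at hand and both within the scatter of each other, the expected step from compound 2 to compound 3 is none beyond the scatter, a 1.2-fold lower number from compound 2 to compound 3 (0.07 log units; within the scatter). Compound 3 is therefore estimated at 900000 nM, with a range from 400000 nM to 2000000 nM.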

Compound 3, half-maximal cytotoxic concentration: 1390000 nM
Beside the measured number, compound 3's estimate is 1.5-fold (0.19 log units) below it; measured number inside the range.
By their numbers in this assay, from the lowest: compounds 1, 2 and 3 (each within the scatter of the next, the first and the last beyond it).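

In this assay, the one stereocentre at a saturated ring carbon that was changed gives a 1.3-fold higher number from compound 2 to compound 3 (0.12 log units; within the scatter), so this inversion, the first read of a configuration change in the series, does not separate the pair beyond the scatter. The comparison is a clean one for configuration alone: the fact that compounds 2 and 3 differ only in the configuration as drawn

On the aromatic carbon, hydroxymethyl in place of 4-nitrophenyl gives a 2.4-fold higher number from compound 1 to compound 3 (0.37 log units; beyond the scatter), a modest step toward lower toxicity in this test and the only one so far beyond the scatter.

The second stereocentre remains open, since its configuration has not been varied on its own among the compounds shown. Also open, going by these compounds, is whether an amine, a carboxylic acid or a longer chain in place of hydroxymethyl on that aromatic carbon would shift the number.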